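Second chloro on the aryl ring of compound 2

A few compounds are considered here, and "the series" means these few. Any claim that something is new, unique, unknown or untested is made for them only; others in the source may bear on it.

Measured in an ADME assay on HEp-2 cells (Homo sapiens) for cytotoxicity, read by MTT assay, with a stated time of 3 days; on this read-out lower numbers stand for higher toxicity in this test and higher numbers for lower toxicity in this test:
compound 1 `CCCC[C@H](CCn1cncn1)c1ccccc1`: 50.2 ug/mL
compound 2 `CCCC[C@H](CCn1cncn1)c1ccc(Cl)cc1`: 20.2 ug/mL
compound 3 `CCCC[C@@H](CCn1cncn1)c1ccc(Cl)cc1`: 17 ug/mL

Compound 2 stands second highest of the three numbers. Its nearest neighbour is compound 3, a 1.2-fold lower number from compound 2 to compound 3 (0.07 log units; within the scatter), a step that stays small, consistent with the fact that compounds 2 and 3 differ only in the configuration as drawn. Furthest is compound 1, a 2.5-fold lower number from compound 1 to compound 2 (0.40 log units; beyond the scatter).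

Compound 4 `CCCC[C@H](CCn1cncn1)c1ccc(Cl)cc1Cl` differs from compound 2 by chloro in place of hydrogen on an aromatic carbon. Going by the values given here, the one measured step of the same kind is a 2.5-fold lower number from compound 1 to compound 2 (0.40 log units; beyond the scatter), which was modest and ran toward a lower number. A second chloro at a different place on the same ring is expected to move the number in the same direction by a similar or smaller amount, so the expected step is a 1.7-fold lower number from compound 2 to compound 4 (0.23 log units; within the scatter). For compound 4 the estimate in this assay is 12 ug/mL, with a range from 6 ug/mL to 25 ug/mL.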

Compound 4, half-maximal cytotoxic concentration: 13.4 ug/mL
Compound 4: the middle estimate sits 1.1-fold (0.05 log units) below what was measured, within the range that was stated.
By their numbers in this assay, from the lowest: compounds 4, 3 and 2 (each within the scatter of the next); then compound 1.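

In this assay, chloro in place of hydrogen ortho to a large group and meta to a chloro group gives a step within the scatter (a 1.5-fold lower number from compound 2 to compound 4 (0.18 log units; within the scatter)), unlike the earlier chloro step, which lay beyond it (a 2.5-fold lower number from compound 1 to compound 2 (0.40 log units; beyond the scatter)). Going by these compounds alone, at this position, a second chloro therefore gives no step that can be told from the scatter. Nothing at hand bears on the cause of this step.

Still open, on these data alone, is how a methoxy group, an amine or a carboxylic acid would read at this position. Also open, as far as these compounds go, is how compound 4 would read with its stereocentre drawn the other way.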